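The source may hold more compounds than are shown below. What is called first, only, known or untested is meant among the compounds shown, and "the series" means these compounds.

In an assay on CHO-K1 cells for antagonist activity at adenosine receptor A1 (Homo sapiens), read by a beta-galactosidase reporter, with stated times of 15 min and 6 h (a higher number here means a weaker inhibitor, a lower number a stronger inhibitor), compound 2, with the structure `Nc1nc(-c2cc3ccccc3o2)nc2sc(CN3CCC(F)CC3)cc12`, gives 630 nM. That is the lower of the two numbers obtained so far; compound 1, with the structure `Nc1nc(-c2ccco2)nc2sc(CN3CCC(F)(F)CC3)cc12`, gives 2230 nM in this assay, and the two compounds differ at more than one place, so their values are simply set side by side without a single step being drawn between them.

Compound 3, with the structure `N#Cc1ccc(-c2nc(N)c3cc(CN4CCC(F)CC4)sc3n2)cc1`, has not yet been measured in this assay. It departs from compound 2 in one place: 4-cyanophenyl in place of 1-benzofuran-2-yl on an aromatic carbon. Among the measured compounds shown here, with no measured pair in this set that isolates this change, the direction can only be expected rather than read off. The expected step of a 2.4-fold higher number from compound 2 to compound 3 (0.38 log units; beyond the scatter) points toward a higher number, that is a weaker inhibitor, by an amount that is estimated to reach beyond the usual scatter but not by a wide margin. On that basis compound 3 is expected to give 1500 nM in this assay, estimated to fall between 400 nM and 6000 nM.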

Compound 3, inhibition constant: 8430 nM
Beside the measured number, compound 3's estimate is 5.6-fold (0.75 log units) below it, and the stated range ends below it.
By their numbers in this assay, from the lowest: compound 2; then compound 1; then compound 3.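

In this assay, placing 4-cyanophenyl instead of 1-benzofuran-2-yl on the aromatic carbon between two ring nitrogen atoms gives a 13-fold higher number from compound 2 to compound 3 (1.13 log units; beyond the scatter), a large step and the first in this set that isolates a change at a single place. It shows that the number at this position depends strongly on the group carried there, even though the group leaving and the group entering have the same counts of hydrogen-bond donors and acceptors and neither has a net charge. No measurement at hand bears on the cause of this step.

The step exchanges a five-membered aromatic ring with oxygen and a six-membered carbon ring for a single six-membered carbon ring bearing a nitrile, so it leaves open how much of the change belongs to the ring system and how much to the nitrile. On these data alone, it also remains open whether a plain phenyl group, or a phenyl group carrying an amine or a carboxylic acid where the nitrile stands, would give a number closer to that of compound 2 or compound 3.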